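A Cyclopentyl Swapped for a Dimethylaminoethyl Chain

The source may report more compounds than this note shows. Statements on the series, on what has been measured and on what is new or still open speak of the compounds shown alone.

The measurements come from a functional assay for inhibition, with Homo sapiens as the target; on this read-out higher numbers stand for weaker inhibition and lower numbers for stronger inhibition. Within the data shown here, compound 1 `CC(C)CCSc1nncc2cncn12` gives 9000 nM, the only plain number among the three. Compound 2 `c1ncn2c(NC3CCCC3)nncc12` reaches only > 48000 nM, which is a limit of this assay rather than a number. Compound 3 `CC(=O)N(C1=NNCC1)c1nncc2c(C)ncn12` likewise shows only > 48000 nM, again a limit. Compound 2 therefore stands at the limit of > 48000 nM in this assay, at which 2 of the 3 values shown sit, so nothing is known about its inhibition beyond that it is weak.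

Compound 4 `CN(C)CCNc1nncc2cncn12` has not yet been measured. It differs from compound 2 in one place, (2-(dimethylamino)ethyl in place of cyclopentyl on a nitrogen on an aromatic ring).

Among the measured compounds shown here, no pair of measured compounds differs in only one place, so no measured step guides the expectation; the change can only be judged against the limit of compound 2 and the modest number of compound 1. The expected step of an at least 1.6-fold lower number from compound 2 to compound 4 (0.20 log units; that floor lies within the scatter) is toward somewhat stronger inhibition, though it may well stay within the scatter. Compound 4 is expected to give about 30000 nM, in a range from 8000 nM to 100000 nM.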

Compound 4, half-maximal inhibitory concentration: > 48000 nM
Compound 4 ended at the assay's limit; the forecaster's own chance of this, stated with the estimate: 45%; at least 1.6-fold (0.20 log units) between middle value and limit.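

Among these compounds, compound 2 and compound 4 both sit at a limit of this assay rather than at a number, so no step between them can be read: the limit of > 48000 nM in this assay, at which 3 of the 4 values shown sit. The compounds shown leave open whether 2-(dimethylamino)ethyl in place of cyclopentyl changes inhibition at all.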